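The compounds below may be only part of what the source reports. "The series", "measured", "known", "first", "only" and "open" are said of these compounds alone.

Series in a functional assay on HCT-116 cells (Homo sapiens) for inhibition, read by CCK-8 assay, with a stated time of 48 h; on this read-out lower numbers stand for stronger inhibition and higher numbers for weaker inhibition:
- compound 1 `COc1ccc(CN(C(=O)CSC(=S)N2CCN(C)CC2)c2cc(OC)c(OC)c(OC)c2)cc1`: 2640 nM
- compound 2 `COc1ccc(CN(C(=O)CSC(=S)N2CCN(C(=O)OC(C)(C)C)CC2)c2cc(OC)c(OC)c(OC)c2)cc1`: 620 nM
- compound 3 `COc1cc(N(Cc2ccc(C)cc2)C(=O)CSC(=S)N2CCN(C(=O)OC(C)(C)C)CC2)cc(OC)c1OC`: > 20000 nM (a limit, not a number)

Compound 3 stands at the limit of > 20000 nM in this assay, at which 1 of the 3 values shown sits. Its true value is therefore not known, and any step away from it can only be read against that limit.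

Compound 4 `COc1ccc(CN(C(=O)CSC(=S)N2CCN(C(=O)OC(C)(C)C)CC2)c2cc(OC)c(OC)c(OC)c2)cc1Br` differs from compound 3 by 3-bromo-4-methoxyphenyl in place of 4-methylphenyl on a saturated chain carbon bound to an amide-type nitrogen. In words, this is 3-bromo-4-methoxyphenyl in place of 4-methylphenyl on a saturated chain carbon bound to an amide-type nitrogen.

The most relevant measured step is an at least 32-fold higher number from compound 2 to compound 3 (1.50 log units; beyond the scatter), where methyl replaced methoxy on an aromatic carbon. The entering group in compound 4 carries methoxy again, so much of that large loss is expected to be recovered. The other step, a 4.3-fold lower number from compound 1 to compound 2 (0.63 log units; beyond the scatter), concerns tert-butoxycarbonyl in place of methyl on an amine nitrogen in a ring. Compound 3 and compound 4 both carry tert-butoxycarbonyl, so this step does not bear directly on the change. For the measured compounds named here, no measured compound carries bromine, so its contribution is open and the range is kept wide.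

A large move toward stronger inhibition is expected, estimated as an at least 20-fold lower number from compound 3 to compound 4 (1.30 log units; beyond the scatter). For compound 4 the estimated value is 1000 nM, with an expected range of 150 nM to 7000 nM.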

Compound 4, half-maximal inhibitory concentration: 9710 nM
Beside the measured number, compound 4's estimate is 9.7-fold (0.99 log units) below it; measured number above the stated range.
By their numbers in this assay, from the lowest: compound 2; then compound 1; then compound 4. At a limit, above all of these: compound 3.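

In this assay, bromo in place of hydrogen on an aromatic carbon gives a 16-fold higher number from compound 2 to compound 4 (1.19 log units; beyond the scatter), so the ring that carries the methoxy group in compound 2 responds strongly to a change other than the swap of methoxy for methyl. Set against the 4-methylphenyl group, 3-bromo-4-methoxyphenyl on a saturated chain carbon bound to an amide-type nitrogen gives an at least 2.0-fold lower number from compound 3 to compound 4 (0.31 log units; beyond the scatter), which shows that part of the activity lost at this position can be regained, though the level of compound 2 at 620 nM is not reached. The size of that gain is only a lower bound, since compound 3 sits at a limit and not at a number: the limit of > 20000 nM in this assay, at which 1 of the 4 values shown sits.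

Going by these compounds, whether fluoro, chloro or hydroxy in place of the bromo would keep the activity of compound 2 stays open. Also open, on these data alone, is whether the cost of the bromo carries over when methyl replaces tert-butoxycarbonyl on the amine nitrogen in a ring, as in compound 1.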